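Pyridin-3-yl in place of 2-methylphenyl at the imidazole carbon

The source may report more compounds than this note shows. Statements on the series, on what has been measured and on what is new or still open speak of the compounds shown alone.

Measured so far:
compound 1, `Cn1c(-c2ccccc2)nc2c(NC3CCCC3)ncnc21`: 8510 nM
compound 2, `Cn1c(-c2cccc(Cl)c2)nc2c(NC3CCCC3)ncnc21`: 2530 nM
compound 3, `Cc1ccccc1-c1nc2c(NC3CCCC3)ncnc2n1C`: > 30000 nM

All three share one core and differ only in the aryl group on the five-membered ring. In a functional assay on CHO cells for antagonist activity at adenosine receptor A2b (Homo sapiens), read by 33P incorporation, with a stated time of 20 min (on this read-out higher numbers stand for weaker inhibition and lower numbers for stronger inhibition), compound 1 gives 8510 nM and compound 2 gives 2530 nM, a step of a 3.4-fold lower number from compound 1 to compound 2 (0.53 log units; beyond the scatter). For compound 3 this assay reports only a limit, > 30000 nM (the limit of > 30000 nM in this assay, at which 1 of the 3 values shown sits). Thus compound 3 stands at the weak end of the set: the step of an at least 3.5-fold higher number from compound 1 to compound 3 (0.54 log units; beyond the scatter) and the step of an at least 11-fold higher number from compound 2 to compound 3 (1.07 log units; beyond the scatter) both run toward weaker inhibition.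

Compound 4, `Cn1c(-c2cccnc2)nc2c(NC3CCCC3)ncnc21`, is not yet measured. Its change from compound 3 is pyridin-3-yl in place of 2-methylphenyl on an aromatic carbon. Among the compounds with values here, the steps that bear on it are those into compound 3, since the 2-methylphenyl that leaves is the group whose arrival, as an at least 3.5-fold higher number from compound 1 to compound 3 (0.54 log units; beyond the scatter) and an at least 11-fold higher number from compound 2 to compound 3 (1.07 log units; beyond the scatter) show, pushed the number past the limit. Within the data shown here, removing it is expected to bring compound 4 back near the range of compound 1, while the pyridin-3-yl itself has no measured precedent here. In this assay compound 4 is therefore expected to give 10000 nM, between 3000 nM and 30000 nM. For compound 4 this estimate means a step of an at least 3.0-fold lower number from compound 3 to compound 4 (0.47 log units; beyond the scatter), downward, beyond the scatter.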

Compound 4, inhibition constant: > 30000 nM
Compound 4 gave a limit, no number (the forecaster's own chance of this, stated with the estimate: 25%); middle value at least 3.0-fold (0.47 log units) away from the limit.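

The change from phenyl to pyridin-3-yl gives an at least 3.5-fold higher number from compound 1 to compound 4 (0.54 log units; beyond the scatter), so at this aromatic carbon a ring without any methyl group, carrying one ring nitrogen, also falls out of the measurable range, and the 2-methylphenyl of compound 3 is no longer the only group shown to do so. Against the 3-chlorophenyl group the result is an at least 11-fold higher number from compound 2 to compound 4 (1.07 log units; beyond the scatter), which leaves compound 2 as the only compound shown with a lower number than compound 1. Compound 3 and compound 4 each sit at a limit in this assay, and the step between them cannot be read: the limit of > 30000 nM in this assay, at which 2 of the 4 values shown sit.

The compounds shown leave open how much of the change rests on the ring nitrogen itself, and whether pyridin-2-yl or pyridin-4-yl would behave alike. They also leave open whether a methoxy group or an amine on the phenyl ring would give a lower number than compound 2 does.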